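This account rests on a few compounds, and the source may have more. Where it says the series, first, only, none or still open, it means among the compounds named here.

In a functional assay on MDA-MB-435 cells (Homo sapiens) for cytotoxicity, read by MTT assay, with a stated time of 72 h (a lower number here means a stronger inhibitor, a higher number a weaker inhibitor), compound 1 `O=C(NCc1ccc(F)cc1)c1nc(Br)c2cccnc2c1NCc1ccc(F)cc1` gives > 20000 nM, which is a limit of the assay rather than a number. Compound 1 therefore stands at the limit of > 20000 nM in this assay, at which 1 of the 3 values shown sits. Compound 2 `N[C@H]1CC[C@H](NC(=O)c2nc(Br)c3cccnc3c2NCc2ccc(F)cc2)CC1` gives 6600 nM, and compound 3 `N[C@H]1CC[C@H](Nc2c(C(=O)NCc3cccc(C(F)(F)F)c3)nc(Br)c3cccnc23)CC1` gives 4200 nM. Compound 4 `O=C(NCc1ccc(F)cc1)c1nc(Br)c2cccnc2c1NCc1ccccc1` differs from compound 1 by hydrogen in place of fluoro on an aromatic carbon. Among the measured compounds shown here, the only measured step touching this part of the molecule is an at least 3.0-fold lower number from compound 1 to compound 2 (0.48 log units; beyond the scatter), which exchanges the whole 4-fluorobenzyl group rather than a single atom, so it does not test fluoro against hydrogen. For the measured compounds named here, with no step of that kind available, no change beyond the scatter in this assay is expected, and compound 4 will most likely also sit at the limit. The estimate for compound 4 is 25000 nM, between 10000 nM and 60000 nM. Against compound 1 that estimate means an expected step that the limit leaves unreadable from compound 1 to compound 4.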

Compound 4, half-maximal inhibitory concentration: > 20000 nM
Compound 4 was reported as a limit; the forecaster's own chance of this, stated with the estimate: 75%; the middle value is on the limit's open side.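

Compound 1 and compound 4 are both reported only as limits, not numbers, so no step between them can be read: the limit of > 20000 nM in this assay, at which 2 of the 4 values shown sit.

The compounds shown leave open whether benzylamino in place of (4-fluorobenzyl)amino changes the cytotoxicity at all.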